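Swapping acetyl for dimethylamino on compound 1

The source may hold more compounds than are shown below. What is called first, only, known or untested is meant among the compounds shown, and "the series" means these compounds.

Measured so far:
compound 1 `COc1cc(C)cc(-c2c(-c3ccnc(-c4ccc(C(C)=O)cc4)c3)cnn2CC#N)c1`: 97%
compound 2 `COc1cc(C)cc(-c2nn(CC#N)cc2-c2ccc(-c3cccc(C(C)=O)c3)nc2)c1`: 101%
compound 3 `Cc1cc(O)cc(-c2nn(CC#N)cc2-c2ccnc(-c3ccc(N(C)C)cc3)c2)c1`: 95%

In a functional assay on HCT-116 cells (Homo sapiens) for cytotoxicity, read by sulforhodamine B assay, with a stated time of 48 h, tested at 0.001 uM (a higher number here means a weaker effect of the compound at the concentration tested, a lower number a stronger effect), compound 1 gives 97%, the second highest of the three numbers. Its nearest neighbour is compound 3 at 95%, and the furthest is compound 2 at 101%; both gaps lie within the scatter, so the three values cannot be told apart.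

Compound 4 `COc1cc(C)cc(-c2c(-c3ccnc(-c4ccc(N(C)C)cc4)c3)cnn2CC#N)c1` differs from compound 1 in one place: dimethylamino in place of acetyl on an aromatic carbon. Compound 3, which also carries dimethylamino, gives 95%, a number indistinguishable from that of compound 1. No step beyond the scatter is therefore expected in this assay; the estimated step of no change at the digits printed from compound 1 to compound 4 (within the scatter) is essentially flat. Compound 4 is estimated at 97%, with a range from 88% to 106%.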

Compound 4, a percentage reported as activity, at one concentration (the size of the read-out at that concentration, not a potency): 102%
Beside the measured number, compound 4's estimate is 5 percentage points below it, and the stated range covers the measured number.
By their numbers in this assay, from the lowest: compounds 3, 1, 2 and 4 (each within the scatter of the next).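

In this assay, going by these compounds alone, replacing acetyl with dimethylamino gives a number 5 percentage points higher from compound 1 to compound 4 (within the scatter) and provides the first comparison here of two compounds that differ in one place. On this evidence, 4-acetylphenyl and 4-(dimethylamino)phenyl cannot be told apart at this single low concentration. Nothing available explains this result. On these data alone, whether a carboxylic acid or a longer chain at this place would give a number beyond the scatter remains open. So does whether acetyl and dimethylamino would separate at higher concentrations.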